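The compounds below may be only part of what the source reports. "The series", "measured", "known", "first", "only" and "open" are said of these compounds alone.

For the measured compounds named here, in an ADME assay on microsomes from liver (Rattus norvegicus) for metabolic stability (on this read-out lower numbers stand for a shorter-lived compound and higher numbers for a longer-lived compound), compound 1 (`CC(C)(O)COc1ccc2c(Oc3ccc(Nc4nccc5[nH]cc(-c6ccc(F)cc6)c(=O)c45)cc3F)ccnc2c1`) gives 4.14 h as the highest of the three numbers measured so far. Compound 2 (`CC(C)COc1ccc2c(Oc3ccc(Nc4nccc5[nH]cc(-c6ccc(F)cc6)c(=O)c45)cc3F)ccnc2c1`) gives 1.5 h and compound 3 (`COC(C)(C)COc1ccc2c(Oc3ccc(Nc4nccc5[nH]cc(-c6ccc(F)cc6)c(=O)c45)cc3F)ccnc2c1`) gives 1.45 h on the same read-out. Compound 4 (`COCCOc1ccc2c(Oc3ccc(Nc4nccc5[nH]cc(-c6ccc(F)cc6)c(=O)c45)cc3F)ccnc2c1`) is still unmeasured. It differs from compound 1 as methoxymethyl in place of 1-hydroxy-1-methylethyl on a saturated chain carbon bound to an oxygen on an aromatic ring shows, with methoxymethyl in place of 1-hydroxy-1-methylethyl on a saturated chain carbon bound to an oxygen on an aromatic ring, which turns 2-hydroxy-2-methylpropoxy into 2-methoxyethoxy.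

Two measured steps also lose the free hydroxy of compound 1. Putting hydrogen in its place gives a 2.8-fold lower number from compound 1 to compound 2 (0.44 log units; beyond the scatter) and putting methyl on its oxygen gives a 2.9-fold lower number from compound 1 to compound 3 (0.46 log units; beyond the scatter) so both steps are modest yet beyond the scatter. The remaining step of a 1.0-fold lower number from compound 2 to compound 3 (0.01 log units; within the scatter) stays within the scatter, so the two routes agree. Going by the values given here, no measured compound carries 2-methoxyethoxy itself, which leaves this comparison indirect. For compound 4 a step of a 3.0-fold lower number from compound 1 to compound 4 (0.47 log units; beyond the scatter) is expected, downward and similar in size to those two. Compound 4 is expected at 1.4 h (estimated range 0.7 h to 2.6 h).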

Compound 4, half-life: 1.73 h
For compound 4 the middle estimate is 1.2-fold (0.09 log units) below the measured one; measured number inside the range.
By their numbers in this assay, from the lowest: compounds 3, 2 and 4 (each within the scatter of the next); then compound 1.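

In this assay, replacing the branched 2-hydroxy-2-methylpropoxy with 2-methoxyethoxy gives a 2.4-fold lower number from compound 1 to compound 4 (0.38 log units; beyond the scatter) and so adds a third compound without the hydrogen-bond donor that stands apart from compound 1, this time with the smaller methoxymethyl group in place of 1-hydroxy-1-methylethyl. Among the compounds lacking that free hydroxy, the shape of the chain makes no readable difference: a 1.2-fold higher number from compound 3 to compound 4 (0.08 log units; within the scatter) and a 1.2-fold higher number from compound 2 to compound 4 (0.06 log units; within the scatter) both leave the numbers within the scatter, so methoxymethyl, 1-methoxy-1-methylethyl and isopropyl cannot be told apart at this position. Of the four compounds shown, only compound 1 carries a free hydroxy and only compound 1 stands apart, yet no measurement here bears on why these two facts coincide.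

The compounds shown leave open whether a free hydroxy is enough on its own or works only on the branched chain, which a 2-hydroxyethoxy group would test. They also leave open how an amine or a carboxylic acid on this chain would behave in this assay at this position.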